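The compounds below may be only part of what the source reports. "The series", "measured", "known", "first", "only" and "open" are said of these compounds alone.

Measured compounds:
- compound 1 `COC(=O)/C=C/c1cccc(N(Cc2ccc(/C=C/c3cccc(F)c3)cc2)C(=O)C2CCCCC2)c1`: 86 nM
- compound 2 `COC(=O)/C=C/c1cccc(N(Cc2ccc(-c3cccc(C)c3)cc2)C(=O)C2CCCCC2)c1`: 109 nM
- compound 3 `COC(=O)/C=C/c1cccc(N(Cc2ccc(-c3cccc(C)c3)cc2)C(=O)C(C)C)c1`: 163 nM

In an assay on isolated protein with Bile acid receptor (Homo sapiens) as the target (a higher number here means that more compound is needed for the effect, a lower number that less compound is needed), compound 2 stands second highest of the three numbers; the gap to compound 1, a 1.3-fold higher number from compound 1 to compound 2 (0.10 log units; within the scatter), and the gap to compound 3, a 1.5-fold higher number from compound 2 to compound 3 (0.17 log units; within the scatter), are both within the scatter. Compound 4 `COC(=O)/C=C/c1cccc(N(Cc2ccc(C(C)(C)C)cc2)C(=O)C2CCCCC2)c1` is the unmeasured partner: tert-butyl in place of 3-methylphenyl on an aromatic carbon. Of the two measured steps, only a 1.3-fold higher number from compound 1 to compound 2 (0.10 log units; within the scatter) touches the same aromatic carbon, and it swapped one ring-bearing group for another with hardly any shift. For the measured compounds named here, no measured step replaces a ring with a chain. The expectation for compound 4 is therefore a step of a 1.4-fold higher number from compound 2 to compound 4 (0.14 log units; within the scatter), not beyond the scatter. Compound 4 is estimated at 150 nM, within 60 nM to 400 nM.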

Compound 4, half-maximal effective concentration: > 1000 nM
Compound 4: only a limit was reported (the forecaster's own chance of this, stated with the estimate: 5%); middle value at least 6.6-fold (0.82 log units) away from the limit.
By their numbers in this assay, from the lowest: compounds 1, 2 and 3 (each within the scatter of the next). At a limit, above all of these: compound 4.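

In this assay, this aromatic carbon carries the ring-bearing groups of compound 1 and compound 2 with little separating them, but that does not extend to tert-butyl, which has no ring: the change brings an at least 9.1-fold higher number from compound 2 to compound 4 (0.96 log units; beyond the scatter), and an at least 11-fold higher number from compound 1 to compound 4 (1.06 log units; beyond the scatter). Compound 4 gives only a limit, not a number: the limit of > 1000 nM in this assay, at which 1 of the 4 values shown sits.

Among these three compounds, then, the two groups containing an aromatic ring go with the lower numbers. As far as these compounds go, whether the aromatic ring itself is what counts stays open: a cyclohexyl group or a longer carbon chain on this carbon would speak to that.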